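Benzylamine variation on a shared nucleoside core: antiproliferation notes

This account rests on a few compounds, and the source may have more. Where it says the series, first, only, none or still open, it means among the compounds named here.

Measured compounds:
compound 1 `COc1ccccc1CNc1ncnc2c1ncn2[C@@H]1O[C@H](CO)[C@@H](O)[C@H]1O` — > 166000 nM
compound 2 `OC[C@H]1O[C@@H](n2cnc3c(NCc4ccc(F)c(F)c4F)ncnc32)[C@H](O)[C@@H]1O` — > 166000 nM

In a functional assay on G-361 cells (Homo sapiens) for antiproliferative activity, with a stated time of 72 h (a higher number here means a weaker inhibitor, a lower number a stronger inhibitor), compound 1 gives > 166000 nM, which is a limit of the assay rather than a number. Compound 2 likewise stands at a limit of the assay, > 166000 nM. The step that the two limits leave unreadable from compound 1 to compound 2 cannot be read because both values sit at the limit of > 166000 nM in this assay, at which 2 of the 2 values shown sit. Compound 3 `OC[C@H]1O[C@@H](n2cnc3c(NCc4cccc(C(F)(F)F)c4)ncnc32)[C@H](O)[C@@H]1O` carries the change (3-(trifluoromethyl)phenyl in place of 2-methoxyphenyl on a saturated chain carbon bound to a nitrogen on an aromatic ring). Among the measured compounds shown here, the only measured step bearing on it, from compound 1 to compound 2, has no readable size, so no direction beyond the scatter can be expected. Compound 3 is expected to stand at the limit again, estimated at 250000 nM with a range from 100000 nM to 600000 nM. The step that the limit leaves unreadable from compound 1 to compound 3 is expected to remain unreadable.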

Compound 3, half-maximal inhibitory concentration: > 166000 nM
Compound 3 was reported as a limit; the forecaster's own chance of this, stated with the estimate: 85%; the middle value is on the limit's open side.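

The steps linking compound 3 with compound 1 and compound 2 cannot be read, because all three values are limits: the limit of > 166000 nM in this assay, at which 3 of the 3 values shown sit.
The compounds shown leave open whether any change on the benzylamine of the shared core gives a measurable antiproliferative value.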